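The source may hold more compounds than are shown below. What is called first, only, known or untested is meant among the compounds shown, and "the series" means these compounds.

Compound 1, `COc1ccccc1-c1ccn(CCC(C)C)c(=O)c1C#N`: > 10000 nM (a limit, not a number)
Compound 2, `CC(C)CCn1ccc(-c2ccc(OCC3CC3)cc2)c(C#N)c1=O`: 290 nM

Both compounds were tested in a functional assay on CHO cells for positive allosteric modulation of metabotropic glutamate receptor 2 (Homo sapiens), read by scintillation counting and GTPgammaS binding, with a stated time of 30 min; on this read-out lower numbers stand for an effect already at smaller amounts and higher numbers for an effect only at larger amounts of compound. For compound 1 the result is a limit of the assay rather than a measured number: > 10000 nM, which is the limit of > 10000 nM in this assay, at which 1 of the 2 values shown sits. Compound 2 gives 290 nM, and among the results shown this is the only actual number. Compound 3, `CC(C)CCn1ccc(-c2ccc(Oc3ccncc3)cc2)c(C#N)c1=O`, has not yet been measured in this assay. It differs from compound 2 in one place: pyridin-4-yl in place of cyclopropylmethyl on an oxygen on an aromatic ring. Among the compounds with values here, no step between two measured compounds that differ in a single place is available, and compound 1 and compound 2 differ in more than one place, so their two values only show that one reaches a number and the other does not. The expected step from compound 2 to compound 3 is a moderate loss, a 2.8-fold higher number from compound 2 to compound 3 (0.44 log units; beyond the scatter), beyond the usual scatter but well short of the limit. Compound 3 is therefore estimated at 800 nM, within a range from 200 nM to 4000 nM.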

Compound 3, half-maximal effective concentration: 550 nM
Estimate against measurement, compound 3: 1.5-fold (0.16 log units) above, and the stated range covers the measured number.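

Within the data shown here, this is the first comparison in which only one place changes, and it shows that the oxygen on the aromatic ring can carry two very different groups. Going from cyclopropylmethyl, a small three-membered carbon ring on a short link, to pyridin-4-yl, a six-membered aromatic ring with a nitrogen that adds a hydrogen-bond acceptor, gives in this assay a 1.9-fold higher number from compound 2 to compound 3 (0.28 log units; within the scatter), so the two compounds cannot be told apart on this read-out. The compounds shown give no information on why this change is tolerated.

As far as these compounds go, what a phenyl ring on the same oxygen would give remains open, so the part played by the pyridine nitrogen cannot be separated from that of the aromatic ring itself. Also open, from the compounds shown here alone, is how far this tolerance extends, for example to an amine-bearing chain, a carboxylic acid or a longer chain such as butyl at this place, and whether any of these would give a step beyond the usual scatter.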